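A substituent swap on the amide-type nitrogen of compound 3

A few compounds are considered here, and "the series" means these few. Any claim that something is new, unique, unknown or untested is made for them only; others in the source may bear on it.

Compound 1 `O=C(NCCCCC(c1ccc(F)cc1)c1ccc(F)cc1)Nc1ccc([N+](=O)[O-])cc1`: 6470 nM
Compound 2 `O=C(NCCCCC(c1ccc(F)cc1)c1ccc(F)cc1)Nc1cccc(C(F)(F)F)c1`: 3380 nM
Compound 3 `Cc1cccc(NC(=O)NCCCCC(c2ccc(F)cc2)c2ccc(F)cc2)c1`: > 20000 nM, a limit

Compound 3 gives only a limit in a functional assay on MDA-MB-231 cells (Homo sapiens) for cytotoxicity, read by MTT assay, with a stated time of 48 h; a lower number here means a stronger inhibitor, a higher number a weaker inhibitor: it stands at the limit of > 20000 nM in this assay, at which 1 of the 3 values shown sits.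

Compound 4 `O=C(NCCCCC(c1ccc(F)cc1)c1ccc(F)cc1)Nc1ccc(Cl)cc1C(F)(F)F` has 4-chloro-2-(trifluoromethyl)phenyl in place of 3-methylphenyl on an amide-type nitrogen.

The measured steps into compound 3 are an at least 5.9-fold higher number from compound 2 to compound 3 (0.77 log units; beyond the scatter) and an at least 3.0-fold higher number from compound 1 to compound 3 (0.49 log units; beyond the scatter). By contrast, the other measured step is a 1.9-fold lower number from compound 1 to compound 2 (0.28 log units; within the scatter). Compound 4 carries trifluoromethyl, as does compound 2 at 3380 nM, so a lower number is expected in this assay. The expected change is an at least 4.4-fold lower number from compound 3 to compound 4 (0.64 log units; beyond the scatter). For compound 4 the estimated value is 4500 nM, with an expected range of 1500 nM to 15000 nM.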

Compound 4, half-maximal inhibitory concentration: > 20000 nM
Compound 4 ended at the assay's limit; the forecaster's own chance of this, stated with the estimate: 12%; middle value at least 4.4-fold (0.64 log units) away from the limit.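

Trifluoromethyl on the phenyl group does not alone keep a value short of the limit in this assay: 4-chloro-2-(trifluoromethyl)phenyl in place of 3-(trifluoromethyl)phenyl gives an at least 5.9-fold higher number from compound 2 to compound 4 (0.77 log units; beyond the scatter). The same group in place of 4-nitrophenyl gives an at least 3.0-fold higher number from compound 1 to compound 4 (0.49 log units; beyond the scatter). The step from compound 3 to compound 4 cannot be read, as both values are limits: the limit of > 20000 nM in this assay, at which 2 of the 4 values shown sit.

The compounds shown do not separate the effect of the chlorine from that of the trifluoromethyl position, as the two change together in compound 4. From the compounds shown here alone, how a 3-aminophenyl or 3-carboxyphenyl group would read on this amide-type nitrogen remains open.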